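Replacing naphthalen-2-yl with 4-chlorophenyl on the shared core

This account rests on a few compounds, and the source may have more. Where it says the series, first, only, none or still open, it means among the compounds named here.

Of the compounds shown here, two have numbers so far in a functional assay on HeLa cells (Homo sapiens) for inhibition, read by MTT assay, with a stated time of 48 h; on this read-out higher numbers stand for weaker inhibition and lower numbers for stronger inhibition. Compound 1 (`CS(=O)(=O)Nc1ccc(-n2cc(-c3ccccc3)nn2)cc1Oc1ccccc1`) gives 21900 nM and compound 2 (`CS(=O)(=O)Nc1ccc(-n2cc(COc3ccc4ccccc4c3)nn2)cc1Oc1ccccc1`) gives 12800 nM in this test. These two values lie within the usual scatter of each other, so compound 2 stands level with compound 1 and the pair cannot be ranked.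

Compound 3 (`CS(=O)(=O)Nc1ccc(-n2cc(COc3ccc(Cl)cc3)nn2)cc1Oc1ccccc1`) has not yet been measured. In it, 4-chlorophenyl stands in place of naphthalen-2-yl on an oxygen on a saturated carbon (4-chlorophenyl in place of naphthalen-2-yl on an oxygen on a saturated carbon), and the rest of the structure is the same as in compound 2. Among the compounds with values here, no measured pair isolates this change, so the data give no direct guide to its size or direction. With only compound 1 at 21900 nM and compound 2 at 12800 nM to go on, a small change is the cautious expectation in this assay, with no shift beyond the scatter. The estimated step of a 1.3-fold higher number from compound 2 to compound 3 (0.10 log units; within the scatter) is a slight drift towards a higher number. Compound 3 is expected at 16000 nM within an estimated range (7000 nM to 38000 nM).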

Compound 3, half-maximal inhibitory concentration: 7800 nM
The estimate for compound 3 lay 2.1-fold (0.31 log units) above the measured number; the range from low to high includes it.
By their numbers in this assay, from the lowest: compounds 3, 2 and 1 (each within the scatter of the next, the first and the last beyond it).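

On an oxygen on a saturated carbon, going from naphthalen-2-yl to 4-chlorophenyl in this assay gives a 1.6-fold lower number from compound 2 to compound 3 (0.22 log units; within the scatter), so one six-membered aromatic ring carrying a chlorine stands level with the two rings of naphthalen-2-yl, and this position tolerates the exchange without a change that can be read. The series also gains its first step beyond the scatter: (4-chlorophenoxy)methyl in place of phenyl on an aromatic carbon gives a 2.8-fold lower number from compound 1 to compound 3 (0.45 log units; beyond the scatter), a modest step that compound 2, level with compound 1, could not show. Nothing at hand bears on why these numbers fall as they do.

The compounds shown leave open what the chlorine contributes by itself, since a plain phenoxy group on the same carbon would be needed to separate it from the rest of the (4-chlorophenoxy)methyl group. They also leave open whether the step from phenyl depends on the oxygen and its saturated carbon, and how a 4-methoxyphenyl or a 4-aminophenyl group would read on that oxygen.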